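Fluoro for trifluoromethyl on the triazole aryl of compound 4

The source may report more compounds than this note shows. Statements on the series, on what has been measured and on what is new or still open speak of the compounds shown alone.

Measured compounds:
compound 1 `Cc1ccc(S(=O)(=O)Oc2ccc3c(c2C)[C@H](Cn2cc(-c4ccccc4)nn2)[C@@]24CC(=O)[C@@](C)(CC[C@@H]32)C4)cc1`, > 20000 nM
compound 2 `C=C1C[C@]23C[C@@]1(O)CC[C@H]2c1ccc(O)c(C)c1[C@@H]3Cn1cc(-c2ccc(C(F)(F)F)cc2)nn1`, 12400 nM
compound 3 `C=C1C(=O)[C@]23C[C@@]1(O)CC[C@H]2c1ccc(OS(=O)(=O)c2ccc(C)cc2)c(C)c1[C@@H]3Cn1cc(-c2ccc(F)cc2)nn1`, 330 nM

Of the compounds shown here, three on the shared core have been tested in a functional assay on MCF7 cells (Homo sapiens) for cytotoxicity, read by MTT assay, with a stated time of 4 days; on this read-out higher numbers stand for weaker inhibition and lower numbers for stronger inhibition. For compound 1 the result is a limit of the assay, not a number: compound 1 gives > 20000 nM, and this is the limit described as the limit of > 20000 nM in this assay, at which 1 of the 3 values shown sits. Of the two numbers that were obtained, compound 2 has the higher one, giving 12400 nM in this assay, while compound 3 gives 330 nM, a gap that lies beyond the scatter of repeated measurements. For the measured compounds named here, compound 2 and compound 3 differ in several places at once, so their two values show only that the numbers differ and nothing about any single change.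

Compound 4 `C=C1C[C@]23C[C@@]1(O)CC[C@H]2c1ccc(O)c(C)c1[C@@H]3Cn1cc(-c2ccc(F)cc2)nn1` has not yet been measured in this assay. It differs from compound 2 in one place: fluoro in place of trifluoromethyl on an aromatic carbon. Going by the values given here, no measured pair on this core isolates that change, so there is no basis for expecting more than a small step. The author expects compound 4 to give roughly 10000 nM in this assay, within a range from 4000 nM to 25000 nM. The expected step from compound 2 to compound 4 is therefore a 1.2-fold lower number from compound 2 to compound 4 (0.09 log units; within the scatter), within the scatter.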

Compound 4, half-maximal inhibitory concentration: > 20000 nM
Compound 4 gave a limit, no number (the forecaster's own chance of this, stated with the estimate: 20%); middle value at least 2.0-fold (0.30 log units) away from the limit.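

Compound 4 gives a limit of the assay, not a number, and it is the same limit that compound 1 shows: the limit of > 20000 nM in this assay, at which 2 of the 4 values shown sit.

In this assay, the change from 4-(trifluoromethyl)phenyl to 4-fluorophenyl, on an aromatic carbon para to a large group, therefore reads as an at least 1.6-fold higher number from compound 2 to compound 4 (0.20 log units; that floor lies within the scatter). For the compounds shown here, this is the first pair on the shared core that isolates this place, and it shows that fluoro there gives no lower number than trifluoromethyl, although a floor within the scatter does not by itself establish a real loss.

Going by these compounds, how far the value of compound 4 lies past the limit remains unknown, so the true size of the step cannot be told from these compounds. On these data alone, it also remains open whether a chloro group, a methoxy group, a nitrile or an amine at this place would give a lower number than compound 2, and whether the same change would read alike on a version of the core carrying different groups elsewhere.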